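A few compounds are considered here, and "the series" means these few. Any claim that something is new, unique, unknown or untested is made for them only; others in the source may bear on it.

Of the compounds shown here, three have so far been measured in an in vitro ADME assay on microsomes (Homo sapiens) for metabolic stability; a higher number here means faster removal of the compound, a lower number slower removal: compound 1 `O=C(CN(C(=O)c1ccc(-c2ccccn2)cc1)C1CCCCC1)Nc1cc(F)cc(F)c1`, compound 2 `O=C(CN(CC1CC1)C(=O)c1ccc(-c2ccccn2)cc1)Nc1cc(F)cc(F)c1` and compound 3 `O=C(CN(C(=O)c1ccc(-c2ccccn2)cc1)C1CCOCC1)Nc1cc(F)cc(F)c1`. In this assay compound 1 gives 5.2 mL.min-1.g-1. Compound 2 gives only a limit of the assay, < 0.5 mL.min-1.g-1. Compound 3 likewise gives only a limit of the assay, < 0.5 mL.min-1.g-1.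

Compound 2 therefore stands at the low edge of what this assay reports, and it shares that position with compound 3, as the limit of < 0.5 mL.min-1.g-1 in this assay, at which 2 of the 3 values shown sit, shows. The measured steps are an at least 10-fold lower number from compound 1 to compound 2 (1.01 log units; beyond the scatter) and an at least 10-fold lower number from compound 1 to compound 3 (1.01 log units; beyond the scatter), while the step that the two limits leave unreadable from compound 2 to compound 3 cannot be sized. Compound 4 `O=C(CN(CC1CCC1)C(=O)c1ccc(-c2ccccn2)cc1)Nc1cc(F)cc(F)c1` is the next compound, differing from compound 2 by cyclobutyl in place of cyclopropyl on a saturated chain carbon bound to an amide-type nitrogen. Among the measured compounds shown here, no measured step covers this particular ring change; the only sized steps concern the replacement of cyclohexyl, and both are large drops into the limit. The change from compound 2 to compound 4 is smaller than either of those, so compound 4 is expected to stay close to compound 2, with a step of an at least 1.2-fold higher number from compound 2 to compound 4 (0.07 log units; that floor lies within the scatter) that is expected to lie within the scatter. Compound 4 is estimated at 0.6 mL.min-1.g-1, with a range from 0.3 mL.min-1.g-1 to 1.8 mL.min-1.g-1, and it may again be reported only as a limit.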

Compound 4, intrinsic clearance in microsomes: 2 mL.min-1.g-1
The estimate for compound 4 lay 3.3-fold (0.52 log units) below the measured number; the whole stated range lies below it.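

The ring change alone gives an at least 4.0-fold higher number from compound 2 to compound 4 (0.60 log units; beyond the scatter), so in this assay this place on the chain responds to cyclobutyl in place of cyclopropyl, whereas the earlier sized steps concerned only the replacement of cyclohexyl. Cyclobutylmethyl also separates from the groups on either side, with an at least 4.0-fold higher number from compound 3 to compound 4 (0.60 log units; beyond the scatter) and a 2.6-fold lower number from compound 1 to compound 4 (0.41 log units; beyond the scatter), so compound 4 lies in the open range of the assay, clear of cyclohexyl and of the limit. The steps starting from compound 2 and compound 3 are floors and not sizes, all set by one limit of the assay: the limit of < 0.5 mL.min-1.g-1 in this assay, at which 2 of the 4 values shown sit.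

The step from compound 2 to compound 3 remains unreadable, since both values are limits. The compounds shown leave open what a cyclopentylmethyl group, an open isobutyl chain or an oxetan-3-ylmethyl group would give on this nitrogen.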